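Working notes: from bromo to nitro in the series

The source may hold more compounds than are shown below. What is called first, only, known or untested is meant among the compounds shown, and "the series" means these compounds.

Values in a functional assay on HT-29 cells (Homo sapiens) for antiproliferative activity, read by sulforhodamine B assay, with a stated time of 48 h; a higher number here means a weaker inhibitor, a lower number a stronger inhibitor:
- compound 1 `CN1CCN(c2ccc(S(=O)(=O)Oc3cccc(F)c3)cc2)C1=O`: > 100000 nM (a limit of the assay, (the limit of > 100000 nM in this assay, at which 1 of the 3 values shown sits))
- compound 2 `CN1CCN(c2ccc(S(=O)(=O)Oc3cccc(Cl)c3)cc2)C1=O`: 2100 nM
- compound 3 `CN1CCN(c2ccc(S(=O)(=O)Oc3cccc(Br)c3)cc2)C1=O`: 1300 nM

Compound 3 at 1300 nM and compound 2 at 2100 nM lie within the scatter of each other, as a 1.6-fold lower number from compound 2 to compound 3 (0.21 log units; within the scatter) shows. The next change gives compound 4 `CN1CCN(c2ccc(S(=O)(=O)Oc3cccc([N+](=O)[O-])c3)cc2)C1=O`, with nitro in place of bromo on an aromatic carbon, meta to a large group: nitro in place of bromo on an aromatic carbon.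

Two large steps bear on this place, an at least 47-fold lower number from compound 1 to compound 2 (1.67 log units; beyond the scatter) and an at least 76-fold lower number from compound 1 to compound 3 (1.88 log units; beyond the scatter), so a single replacement here can move this assay a long way. Neither step replaces a halogen with nitro, which leaves the size of the new step uncertain. A moderate rise in the number is expected, not a return to the limit seen for compound 1, and the range is kept wide. The expected change is a 2.3-fold higher number from compound 3 to compound 4 (0.36 log units; beyond the scatter). For compound 4 the estimated value is 3000 nM, with an expected range of 700 nM to 20000 nM.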

Compound 4, half-maximal inhibitory concentration: 26000 nM
Compound 4: the middle estimate sits 8.7-fold (0.94 log units) below what was measured, and the stated range ends below it.
By their numbers in this assay, from the lowest: compounds 3 and 2 (each within the scatter of the next); then compound 4. At a limit, above all of these: compound 1.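

In this assay, this position separates nitro sharply from the two heavier halogens, a change the halogen steps alone did not show (a 20-fold higher number from compound 3 to compound 4 (1.30 log units; beyond the scatter)) (a 12-fold higher number from compound 2 to compound 4 (1.09 log units; beyond the scatter)). Nitro still does not fall as far as fluoro (an at least 3.8-fold lower number from compound 1 to compound 4 (0.58 log units; beyond the scatter)), which places compound 4 between the pair of compound 2 and compound 3 and the fluoro compound, compound 1. On these data alone, compound 1 stands at a limit of the assay and not at a number, so the full size of that last step stays unknown: the limit of > 100000 nM in this assay, at which 1 of the 4 values shown sits.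

As far as these compounds go, whether an amine, a carboxylic acid or a methyl group on this aromatic carbon would sit with chloro and bromo or with nitro remains open. The compounds shown also give no reason for this order.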